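Adding a Hydroxy Group to a Compound at the Limit

This account rests on a few compounds, and the source may have more. Where it says the series, first, only, none or still open, it means among the compounds named here.

Of the compounds shown here, three have been tested in a functional assay on RS4-11 cells (Homo sapiens) for inhibition, read by CCK-8 assay, with a stated time of 48 h; on this read-out higher numbers stand for weaker inhibition and lower numbers for stronger inhibition. Compound 1 `CC(C)c1ccc(Oc2ccc(O)c(O)c2)c(-c2ccsc2S(=O)(=O)NCCNC(=S)Nc2ccc([N+](=O)[O-])cc2)c1` gives 5100 nM in this assay. Compound 3 `CC(C)c1ccc(Oc2ccc(O)c(O)c2)c(-c2ccsc2S(=O)(=O)NCCNC(=S)Nc2cc(C(F)(F)F)cc(C(F)(F)F)c2)c1` gives 3700 nM in this assay. Both carry two hydroxy groups on one of their rings, and both fall well inside the measurable range of this assay.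

Compound 2 `O=C(NCCNS(=O)(=O)c1ccc(-c2ccccc2OCc2ccccc2)s1)Nc1cc(C(F)(F)F)cc(C(F)(F)F)c1` is different: in this assay it gives only > 50000 nM, which is a limit of the assay and not a number. Among the three values shown, compound 2 is the one that sits at the limit of > 50000 nM in this assay, at which 1 of the 3 values shown sits, so its true inhibition is known only to be weaker than that boundary.

Compound 4 `O=C(NCCNS(=O)(=O)c1ccc(-c2ccccc2OCc2cccc(O)c2)s1)Nc1cc(C(F)(F)F)cc(C(F)(F)F)c1` has not been measured. It differs from compound 2 by hydroxy in place of hydrogen on an aromatic carbon. Going by the values given here, no pair of measured compounds differs in one place, so the size of such a step in this assay cannot be read from the data. Since compound 2 begins at the limit, any step of the expected at least 1.2-fold lower number from compound 2 to compound 4 (0.09 log units; that floor lies within the scatter) would still leave compound 4 close to the limit. Compound 4 is therefore expected to give about 40000 nM in this assay, with a likely range from 15000 nM to 100000 nM.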

Compound 4, half-maximal inhibitory concentration: 3000 nM
Estimate against measurement, compound 4: 13-fold (1.12 log units) above, outside the stated range (below it).
By their numbers in this assay, from the lowest: compounds 4, 3 and 1 (each within the scatter of the next). At a limit, above all of these: compound 2.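

In this assay, putting hydroxy in place of hydrogen on an aromatic carbon, which turns the benzyloxy group into a (3-hydroxybenzyl)oxy group, gives an at least 16-fold lower number from compound 2 to compound 4 (1.22 log units; beyond the scatter). Compound 2 stands at a limit of the assay and not at a number, so this step is only a floor and the true change may be larger: the limit of > 50000 nM in this assay, at which 1 of the 4 values shown sits. This one pair therefore shows that the outer six-membered ring of the benzyloxy group is not a place where changes pass unnoticed, since a single added oxygen atom is enough to bring a compound from the limit into the measurable range.

The compounds shown leave open whether this gain belongs to the hydroxy group itself or would also come with a methoxy group, an amine or a carboxylic acid in the same place. They also leave open what a hydroxy group would do on another carbon of that ring, and whether the same change would give a step of similar size on a different core.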